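Methyl for Bromo: Estimating Compound 4 in Cytotoxicity

The source may report more compounds than this note shows. Statements on the series, on what has been measured and on what is new or still open speak of the compounds shown alone.

Measured compounds:
Compound 1 `C/C(=N\Nc1nc(-c2ccc(Br)cc2)cs1)c1sc(C)nc1C`: in a toxicity assay on HCT-116 cells (Homo sapiens) for cytotoxicity, read by MTT assay (on this read-out lower numbers stand for stronger inhibition of growth and higher numbers for weaker inhibition of growth), compound 1 reaches only the limit > 100 ug/mL.
Compound 2 `C/C(=N\Nc1nc(-c2ccc(C)cc2)cs1)c1sc(C)nc1C`: in this assay compound 2 also reaches only the limit > 100 ug/mL.
Compound 3 `C/C(=N\Nc1nc(-c2ccc(Br)cc2)cs1)c1sc(-c2ccccc2)nc1C`: in this assay compound 3 gives 55.6 ug/mL.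

Compound 3 differs from compound 1 by phenyl in place of methyl on an aromatic carbon, a change that gave an at least 1.7-fold lower number from compound 1 to compound 3 (0.25 log units; that floor lies within the scatter). Compound 4 `C/C(=N\Nc1nc(-c2ccc(C)cc2)cs1)c1sc(-c2ccccc2)nc1C` is not yet measured; it differs from compound 3 by methyl in place of bromo on an aromatic carbon. The same change, (methyl in place of bromo on an aromatic carbon), was already made once and gave a step that the two limits leave unreadable from compound 1 to compound 2, since both values sit at the limit of > 100 ug/mL in this assay, at which 2 of the 3 values shown sit. So nothing measured tells the size of this step in this assay. Compound 4 is therefore expected to stay close to compound 3, with a step of a 1.4-fold higher number from compound 3 to compound 4 (0.16 log units; within the scatter). Compound 4 is estimated at 80 ug/mL, between 35 ug/mL and 160 ug/mL.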

Compound 4, concentration for 50% growth inhibition: > 100 ug/mL
Compound 4 gave a limit, no number (the forecaster's own chance of this, stated with the estimate: 40%); middle value at least 1.2-fold (0.09 log units) from the limit.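

In this assay the change from 4-bromophenyl to 4-methylphenyl on the core of compound 3 gave an at least 1.7-fold higher number from compound 3 to compound 4 (0.25 log units; that floor lies within the scatter) and ended at a limit, so only a lower bound on its size is known. The same change on the core of compound 1 cannot be read, nor can the phenyl-for-methyl step from compound 2 to compound 4. For the compounds shown here, this shows no size that carries from one core to the other, since only one of the two cores gives even a bound: the limit of > 100 ug/mL in this assay, at which 3 of the 4 values shown sit.

The compounds shown carry only bromo or methyl in this place. From the compounds shown here alone, how an amine, a carboxylic acid or a longer chain there would read in this assay remains open.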